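The source may report more compounds than this note shows. Statements on the series, on what has been measured and on what is new or still open speak of the compounds shown alone.

Results in a functional assay on the whole organism with Mus musculus as the target, in the rotarod test (on this read-out lower numbers stand for an effect already at smaller amounts and higher numbers for an effect only at larger amounts of compound), for the two measured compounds:
- compound 1 `NC(=O)/C=C1\CCc2cc(F)cc(F)c21` at 81 mg/kg as measured
- compound 2 `NC(=O)/C=C1\CCc2ccccc21` at 164 mg/kg as measured

Of these two, compound 2 carries the higher number, and its gap to compound 1 lies beyond the usual scatter. Compound 3 `NC(=O)/C=C1\CCc2cc(F)ccc21` differs from compound 2 in one place, with fluoro in place of hydrogen on an aromatic carbon. Among the compounds with values here, no pair of measured compounds shows a single change of this kind, so the expectation rests on the two values alone. A modest move toward a lower number is expected, one that may not clear the scatter, and compound 1 at 81 mg/kg marks the lower number seen so far. The estimated step of a 1.4-fold lower number from compound 2 to compound 3 (0.15 log units; within the scatter) is expected to stay small in this assay on this basis. Compound 3 is expected at 115 mg/kg (estimated range 60 mg/kg to 210 mg/kg).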

Compound 3, dose for half-maximal effect: > 100 mg/kg
Compound 3: a limit, no number; the forecaster's own chance of this, stated with the estimate: 5%; the middle value lies beyond the limit too.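

In this assay compound 3 gives a limit and not a number: the limit of > 100 mg/kg in this assay, at which 1 of the 3 values shown sits.

The step that puts fluoro in place of hydrogen on compound 2 cannot be read, so a single fluoro on this aromatic carbon gains no size of its own from this result. Compared with compound 1, which carries a further fluoro, the limit still leaves an at least 1.2-fold higher number from compound 1 to compound 3 (0.09 log units; that floor lies within the scatter), and as that floor lies within the scatter, it does not show that hydrogen in place of that other fluoro changes the read-out, although a larger step remains possible.

As far as these compounds go, whether compound 3 lies close to compound 1 or far from it stays open. So does the effect of a chloro or a methoxy group on this same aromatic carbon in this assay.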